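This account rests on a few compounds, and the source may have more. Where it says the series, first, only, none or still open, it means among the compounds named here.

Compound 1 `COC(=O)c1ccc(/C=N/Nc2ncnc3sc(C(C)(C)C)cc23)cc1` was included in the set, but in a functional assay on HCT-116 cells (Homo sapiens) for cytotoxicity, read by MTT assay, with a stated time of 3 days (a higher number here means a weaker inhibitor, a lower number a stronger inhibitor), compound 1 gives "not determined" (no result reported). Going by the values given here, compound 2 `CC(C)(C)c1cc2c(N/N=C/c3ccc(CN)cc3)ncnc2s1` is therefore the only compound with a number: in this assay compound 2 gives 0.334 ug/mL. Compound 3 `CC(C)(C)c1cc2c(N/N=C/c3ccc(CO)cc3)ncnc2s1` differs from compound 2 in one place (hydroxy in place of amino on a saturated chain carbon bound to an aromatic carbon). Among the compounds with values here, no measured pair shows this change, so the size of the step is uncertain; a shift no larger than the usual scatter, or at most a modest weakening, is expected in this assay a 1.5-fold higher number from compound 2 to compound 3 (0.18 log units; within the scatter). Compound 3 is thus estimated at 0.5 ug/mL, between 0.15 ug/mL and 1.6 ug/mL.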

Compound 3, half-maximal inhibitory concentration: 0.665 ug/mL
Beside the measured number, compound 3's estimate is 1.3-fold (0.12 log units) below it, and the stated range covers the measured number.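

Replacing the amino group with hydroxy on a saturated chain carbon bound to an aromatic carbon gives a 2.0-fold higher number from compound 2 to compound 3 (0.30 log units; within the scatter) in this assay, so the two compounds cannot be told apart in this assay. At this position, then, the nitrogen of the 4-(aminomethyl)phenyl group can give way to the oxygen of the 4-(hydroxymethyl)phenyl group with no change beyond the scatter. Nothing shown explains this outcome. This is a single pair, so it sets no general rule for the position. Going by these compounds, how a carboxylic acid, a dimethylamine or a longer chain would fare in that place remains open.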